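A few compounds are considered here, and "the series" means these few. Any claim that something is new, unique, unknown or untested is made for them only; others in the source may bear on it.

- compound 1 (`C=C(Br)C(=O)Nc1ccc(/C=C/C(=O)c2cccc(OC)c2)cc1`) with 2700 nM measured
- compound 2 (`C=C(Br)C(=O)Nc1ccc(C(=O)/C=C/c2ccccc2)cc1`) with 690 nM measured
- compound 3 (`C=C(Br)C(=O)Nc1ccc(C(=O)/C=C/c2ccc(OC)cc2)cc1`) with 1000 nM measured

These numbers come from a functional assay on FM3A cells (Mus musculus) for antiproliferative activity, with a stated time of 48 h (on this read-out lower numbers stand for stronger inhibition and higher numbers for weaker inhibition), and form a small series. Compound 3 (1000 nM) stands with compound 2 at the lower end of the three numbers, while compound 1 (2700 nM) lies higher, beyond the scatter. Among the compounds with values here, the one measured step is a 1.4-fold higher number from compound 2 to compound 3 (0.16 log units; within the scatter) for methoxy in place of hydrogen on an aromatic carbon, and it stays within the scatter.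

Compound 4 (`C=C(Br)C(=O)Nc1ccc(C(=O)/C=C/c2cccc(OC)c2)cc1`) differs from compound 3 by 3-methoxyphenyl in place of 4-methoxyphenyl on a double-bonded chain carbon bound to a double-bonded chain carbon with 3-methoxyphenyl in place of 4-methoxyphenyl on a double-bonded chain carbon bound to a double-bonded chain carbon. Within the data shown here, no measured step makes this exchange. Compound 1 also carries 3-methoxyphenyl, but its chain is joined differently, which leaves its value (2700 nM) only a weak guide. In this assay no step beyond the scatter is therefore expected. The estimate means a 1.1-fold higher number from compound 3 to compound 4 (0.04 log units; within the scatter) as an expected step, no larger than the scatter. Compound 4 is expected at 1100 nM within an estimated range (450 nM to 2600 nM).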

Compound 4, half-maximal inhibitory concentration: 1800 nM
For compound 4 the middle estimate is 1.6-fold (0.21 log units) below the measured one; measured number inside the range.
By their numbers in this assay, from the lowest: compounds 2, 3, 4 and 1 (each within the scatter of the next, the first and the last beyond it).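

With 3-methoxyphenyl in place of 4-methoxyphenyl on a double-bonded chain carbon bound to a double-bonded chain carbon, this assay shows a 1.8-fold higher number from compound 3 to compound 4 (0.26 log units; within the scatter) and so does not separate these two placements of the methoxy group. Methoxy in place of hydrogen on an aromatic carbon now gives a 2.6-fold higher number from compound 2 to compound 4 (0.42 log units; beyond the scatter) with 3-methoxyphenyl as the product, the first step of this exchange to pass beyond the scatter, though only modestly, while a 1.4-fold higher number from compound 2 to compound 3 (0.16 log units; within the scatter) with 4-methoxyphenyl stays within it. No evidence is available that would account for either step.

The compounds shown leave open whether an amine, a chlorine atom or a longer chain such as ethoxy in place of the methoxy group would give a different number. They also leave open how the unsubstituted phenyl would read with the chain joined as in compound 1.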